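Replacing 4-chlorophenyl with 3-nitrophenyl on the shared core

A few compounds are considered here, and "the series" means these few. Any claim that something is new, unique, unknown or untested is made for them only; others in the source may bear on it.

In a functional assay on MCF7 cells (Homo sapiens) for cytotoxicity, read by MTT assay, with a stated time of 48 h (a lower number here means a stronger inhibitor, a higher number a weaker inhibitor), compound 1 `CCN(CC)C(=S)SC(CC(=O)c1ccccc1)c1ccc(Cl)cc1` gives 120 nM and stands lowest of the three measured compounds. Compound 2 `CCN(CC)C(=S)SC(CC(=O)c1ccccc1)c1ccc(F)cc1` gives 700 nM and compound 3 `CCN(CC)C(=S)SC(CC(=O)c1ccccc1)c1ccccc1Cl` gives 4500 nM in the same test. Compound 4 `CCN(CC)C(=S)SC(CC(=O)c1ccccc1)c1cccc([N+](=O)[O-])c1` has 3-nitrophenyl in place of 4-chlorophenyl on a saturated chain carbon bound to a saturated chain carbon and a sulfur. For the measured compounds named here, two measured steps bear on this change, with a 5.8-fold higher number from compound 1 to compound 2 (0.77 log units; beyond the scatter) for fluoro in place of chloro and a 38-fold higher number from compound 1 to compound 3 (1.57 log units; beyond the scatter) for 2-chlorophenyl in place of 4-chlorophenyl. Neither tests 3-nitrophenyl directly, but a step of intermediate size toward a higher number is expected, namely a 13-fold higher number from compound 1 to compound 4 (1.10 log units; beyond the scatter) as estimated. Compound 4 is estimated at 1500 nM (expected range 350 nM to 5500 nM).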

Compound 4, half-maximal inhibitory concentration: 9000 nM
The estimate for compound 4 lay 6.0-fold (0.78 log units) below the measured number, and the stated range ends below it.
By their numbers in this assay, from the lowest: compound 1; then compound 2; then compounds 3 and 4 (each within the scatter of the next).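

In this assay, 3-nitrophenyl on this saturated chain carbon gives a 75-fold higher number from compound 1 to compound 4 (1.88 log units; beyond the scatter) and a 13-fold higher number from compound 2 to compound 4 (1.11 log units; beyond the scatter), so a group without halogen also loses much ground against 4-chlorophenyl. Against the other weak member, the step is a 2.0-fold higher number from compound 3 to compound 4 (0.30 log units; within the scatter), which leaves 3-nitrophenyl and 2-chlorophenyl indistinguishable here, and only 4-chlorophenyl and 4-fluorophenyl keep the number low. No evidence is available to explain these differences.

The compounds shown leave open how an unsubstituted phenyl, or a phenyl carrying an amine or a carboxylic acid, would stand at this carbon.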